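This account rests on a few compounds, and the source may have more. Where it says the series, first, only, none or still open, it means among the compounds named here.

- compound 1 `Cc1ccc(-c2cc(NC(=O)c3ccc(Br)nc3)n[nH]2)cc1` reads 7670 nM
- compound 2 `O=C(Nc1cc(-c2ccc(Br)cc2)[nH]n1)c1cccnc1Cl` reads 8220 nM

In a functional assay on A-375 cells (Homo sapiens) for antiproliferative activity, read by MTT assay, with a stated time of 48 h (on this read-out higher numbers stand for weaker inhibition and lower numbers for stronger inhibition), compound 2 gives 8220 nM and stands level with compound 1 at 7670 nM within the scatter. Compound 3 `O=C(Nc1cc(-c2ccc(Br)cc2)[nH]n1)c1ccc(Br)nc1` has not yet been measured. Its change is 6-bromopyridin-3-yl in place of 2-chloropyridin-3-yl on a carbonyl carbon and places 6-bromopyridin-3-yl in place of 2-chloropyridin-3-yl on a carbonyl carbon. Compound 1 already carries that 6-bromopyridin-3-yl group and reads 7670 nM in the same range, so no step beyond the scatter is expected in this assay here. The estimated step is a 1.4-fold lower number from compound 2 to compound 3 (0.14 log units; within the scatter) and is expected to stay small. Compound 3 is expected at 6000 nM (estimated range 2500 nM to 14000 nM).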

Compound 3, half-maximal inhibitory concentration: 9910 nM
Compound 3: the middle estimate sits 1.7-fold (0.22 log units) below what was measured; measured number inside the range.
By their numbers in this assay, from the lowest: compounds 1, 2 and 3 (each within the scatter of the next).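

With the change on a carbonyl carbon, this assay shows a 1.2-fold higher number from compound 2 to compound 3 (0.08 log units; within the scatter) and so does not separate 6-bromopyridin-3-yl from 2-chloropyridin-3-yl at this place. Bromo in place of methyl on an aromatic carbon gives a 1.3-fold higher number from compound 1 to compound 3 (0.11 log units; within the scatter) and also leaves the compounds level in this assay. No measured information on these compounds bears on this result. The compounds shown leave open whether an amine or a carboxylic acid in place of the 6-bromopyridin-3-yl group on the carbonyl carbon would produce a step beyond the scatter.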